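The source may hold more compounds than are shown below. What is called first, only, known or untested is meant among the compounds shown, and "the series" means these compounds.

Working notes, terminal aryl series. Compound 1 `COc1cc(-n2cnc3ccc(-c4ccc(C(F)(F)F)cc4)cc32)cc(OC)c1OC` gives 3390 nM in a functional assay on A549 cells (Homo sapiens) for antiproliferative activity, read by MTT assay, with a stated time of 72 h; a higher number here means a weaker inhibitor, a lower number a stronger inhibitor. Compound 2 `COc1cc(-n2cnc3ccc(-c4cccc(C)c4C)cc32)cc(OC)c1OC` gives 9250 nM in this assay, and compound 3 `COc1cc(-n2cnc3ccc(-c4cccc(C)c4)cc32)cc(OC)c1OC` gives 3820 nM in this assay. Of the three numbers, compound 3 holds the second highest; its nearest neighbour is compound 1, with a 1.1-fold higher number from compound 1 to compound 3 (0.05 log units; within the scatter), and its furthest is compound 2, with a 2.4-fold lower number from compound 2 to compound 3 (0.38 log units; beyond the scatter). The remaining measured step is a 2.7-fold higher number from compound 1 to compound 2 (0.44 log units; beyond the scatter).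

Compound 4 `COc1cc(-n2cnc3ccc(-c4ccc(C)cc4)cc32)cc(OC)c1OC` is the next point. The change from compound 3 is 4-methylphenyl in place of 3-methylphenyl on an aromatic carbon. For the measured compounds named here, no measured step is of the same kind: the two measured steps that are beyond the scatter both involve compound 2 and its 2,3-dimethylphenyl, whereas the step between compound 1 and compound 3, a change of the whole terminal aryl, stays within the scatter. Going by the values given here, the only single-methyl comparison available is the removal in the step from compound 2 to compound 3, which is modest in size. Among the compounds with values here, a rearrangement of the same atoms within a mono-methylated aryl therefore has no direct precedent, and the expected step in this assay is a 1.0-fold lower number from compound 3 to compound 4 (0.00 log units; within the scatter), with no clear direction beyond the scatter.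

Compound 4 is expected to give about 3800 nM in this assay, within a range of 1700 nM to 8500 nM.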

Compound 4, half-maximal inhibitory concentration: 1940 nM
The estimate for compound 4 lay 2.0-fold (0.29 log units) above the measured number; the measured number falls inside the stated range.
By their numbers in this assay, from the lowest: compounds 4, 1 and 3 (each within the scatter of the next); then compound 2.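

Placing the methyl as in the 4-methylphenyl of compound 4 rather than the 3-methylphenyl of compound 3 gives a 2.0-fold lower number from compound 3 to compound 4 (0.29 log units; within the scatter) in this assay, so this rearrangement of the same atoms on the terminal aryl does not separate the two compounds. For the compounds shown here, the first direct exchange at a single place on this aryl, methyl in place of trifluoromethyl, gives a 1.7-fold lower number from compound 1 to compound 4 (0.24 log units; within the scatter), so those two groups are not separated either. Compound 2 remains the only one apart from the rest, and the step from its 2,3-dimethylphenyl to the 4-methylphenyl, a 4.8-fold lower number from compound 2 to compound 4 (0.68 log units; beyond the scatter), is the largest in the set and lies beyond the scatter, making compound 2 the weakest of the four.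

No measurement at hand bears on why the 2,3-dimethylphenyl stands apart or on what underlies any of these steps. Also open, from the compounds shown here alone, is how an amine, a carboxylic acid or a longer chain in place of the methyl of compound 4 would read in this assay, since every group compared so far is a methyl or a trifluoromethyl on the same phenyl.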